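Adding a methoxy group to compound 3

The compounds below may be only part of what the source reports. "The series", "measured", "known", "first", "only" and "open" are said of these compounds alone.

Three compounds have been tested so far in a functional assay on Huh-7 cells (Homo sapiens) for inhibition, read by sulforhodamine B assay, with a stated time of 72 h (a lower number here means a stronger inhibitor, a higher number a weaker inhibitor), and gave these results:
- compound 1 `CCS(=O)(=O)c1ccc(OC)c(Nc2ncc(-c3cc(-c4ccccn4)cc(-c4ccccn4)c3)o2)c1` gives 2800 nM here
- compound 2 `Cc1ccc([S@+]([O-])C2=C(Cl)C(=O)C=CC2=O)cc1` is reported as "not active" (no number reported) without a number
- compound 3 `Cc1ccc([S@+]([O-])C2=CC(=O)C=CC2=O)cc1` gives 20000 nM here

Of the two compounds with a number in this assay compound 3 stands highest with 20000 nM and is the weaker inhibitor of the two, while compound 1 lies lower with 2800 nM by a margin beyond the usual scatter. Compound 2 has no number and cannot be placed on this scale.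

Compound 4 `COC1=CC(=O)C([S@@+]([O-])c2ccc(C)cc2)=CC1=O` has not yet been measured. It differs from compound 3 by a single change methoxy in place of hydrogen on a double-bonded ring carbon with methoxy in place of hydrogen on a double-bonded ring carbon. Among the measured compounds shown here, no measured pair of compounds shows the size of a step of this kind, so the expectation rests on compound 3 with its 20000 nM as the starting point. The estimated change, a 1.4-fold lower number from compound 3 to compound 4 (0.15 log units; within the scatter) in this assay, is expected to stay within the usual scatter, with no firm direction. For compound 4 the expected value is 14000 nM in this measurement, with an estimated range from 4000 nM to 50000 nM around it.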

Compound 4, half-maximal inhibitory concentration: 10600 nM
Compound 4: middle estimate off by 1.3-fold (0.12 log units), on the high side, and the stated range covers the measured number.
By their numbers in this assay, from the lowest: compound 1; then compounds 4 and 3 (each within the scatter of the next).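

Methoxy in place of hydrogen on a double-bonded ring carbon, three ring bonds from the ring atom that bears a group of 9 heavy atoms, gives a 1.9-fold lower number from compound 3 to compound 4 (0.28 log units; within the scatter) in this assay, so this change cannot be told apart from no change at all. This is the first step that can be read among these compounds, and it shows that this ring carbon can carry methoxy while the compound still gives a measurable number, with compound 4 on a par with compound 3 in this assay. Nothing available on these compounds offers an explanation for this result.

Among the compounds shown, this ring carbon bears only hydrogen or methoxy, so it remains open whether an amine, a carboxylic acid or a longer alkoxy chain at the same place would also stay within the scatter of compound 3. Among the compounds shown here, with one step as the only reading, it is also open whether methoxy would behave the same way on a core with a different group on the sulfur.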